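The source may report more compounds than this note shows. Statements on the series, on what has been measured and on what is new or still open speak of the compounds shown alone.

Working notes on the series. Three compounds of the shared core have numbers in a functional assay on MCF7 cells (Homo sapiens) for antiproliferative activity, read by MTT assay, with a stated time of 72 h; on this read-out higher numbers stand for weaker inhibition and lower numbers for stronger inhibition. Compound 1 `COc1cc(-n2cnc3ccc(-c4cccc(C)c4)cc32)cc(OC)c1OC` gives 360 nM. Compound 2 `COc1cc(-n2cnc3ccc(-c4ccc(O)cc4)cc32)cc(OC)c1OC` gives 4160 nM. Compound 3 `COc1cc(-n2cnc3ccc(-c4ccc(C)cc4F)cc32)cc(OC)c1OC` gives 56 nM, the lowest of the three: its nearest neighbour is compound 1, the step of a 6.4-fold lower number from compound 1 to compound 3 (0.81 log units; beyond the scatter) lying beyond the scatter, and the far end is compound 2, with a 74-fold lower number from compound 2 to compound 3 (1.87 log units; beyond the scatter).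

The next step goes from compound 3 to compound 4 `COc1cc(-n2cnc3ccc(-c4ccc(C(C)=O)cc4)cc32)cc(OC)c1OC`, a change at the same aromatic carbon as every step so far: 4-acetylphenyl in place of 2-fluoro-4-methylphenyl on an aromatic carbon

Within the data shown here, two measured steps bear on it. The step of a 6.4-fold lower number from compound 1 to compound 3 (0.81 log units; beyond the scatter) shows what the 2-fluoro-4-methylphenyl group brought over 3-methylphenyl, and that is now given up. The step of a 12-fold higher number from compound 1 to compound 2 (1.06 log units; beyond the scatter) shows that a 4-hydroxyphenyl group, carrying an acceptor, went the wrong way by a large margin. The 4-acetylphenyl group also carries one acceptor, so a higher number is expected, probably of modest to large size. Compound 4 is therefore expected to give about 800 nM, in the range 150 nM to 4000 nM, which means an expected step of a 14-fold higher number from compound 3 to compound 4 (1.15 log units; beyond the scatter).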

Compound 4, half-maximal inhibitory concentration: 1540 nM
The estimate for compound 4 lay 1.9-fold (0.28 log units) below the measured number; the range from low to high includes it.
By their numbers in this assay, from the lowest: compound 3; then compound 1; then compound 4; then compound 2.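

At this aromatic carbon, the presence of an acceptor does not fix the number: acetyl in place of hydroxy recovers part of the loss (a 2.7-fold lower number from compound 2 to compound 4 (0.43 log units; beyond the scatter)), so the two acceptor-bearing groups are separated beyond the scatter. Even so, 4-acetylphenyl falls short of 3-methylphenyl (a 4.3-fold higher number from compound 1 to compound 4 (0.63 log units; beyond the scatter)) and, by more, of 2-fluoro-4-methylphenyl (a 28-fold higher number from compound 3 to compound 4 (1.44 log units; beyond the scatter)); across these four compounds, both methyl-bearing groups give lower numbers than both oxygen-bearing groups, and none goes against this. No measurement available here accounts for these differences.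

Open, as far as these compounds go, is whether an amine or a carboxylic acid in place of the acetyl would fall nearer compound 2 or compound 4. The compounds shown also do not separate the contribution of the fluorine in compound 3 from that of its methyl.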